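The compounds below may be only part of what the source reports. "The series", "measured", "known", "first", "only" and "open" are said of these compounds alone.

Measured compounds in an assay for inhibition of inositol hexakisphosphate kinase 3 (Homo sapiens), read by colorimetric assay, coupled enzyme assay and malachite green, with a stated time of 120 min, in the presence of a further agent that is not named here; on this read-out lower numbers stand for stronger inhibition and higher numbers for weaker inhibition:
- compound 1 `Cc1ccc(-c2onc3ccc(/C=C/C(=O)O)cc23)cc1`: 11500 nM
- compound 2 `O=C(O)/C=C/c1ccc2noc(-c3ccc(-c4ccccc4)cc3)c2c1`: 200 nM
- compound 3 `O=C(O)c1ccc2noc(-c3ccc(-c4cccnc4)cc3)c2c1`: 610 nM

Compound 3 stands second highest of the three numbers; compound 2 gives the lower number and compound 1 the higher one, and both gaps lie beyond the usual scatter. Compound 2 and compound 3 differ in two places at once, so their two values alone cannot be tied to one change.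

Compound 4 `O=C(O)c1ccc2noc(-c3ccc(Oc4ncc(Cl)cc4Cl)cc3)c2c1` differs from compound 3 in one place: (3,5-dichloropyridin-2-yl)oxy in place of pyridin-3-yl on an aromatic carbon. Going by the values given here, only one measured step touches the same region: a 58-fold lower number from compound 1 to compound 2 (1.76 log units; beyond the scatter), where a larger group entered at the position para to the shared core. Among the compounds with values here, that step was large and lowered the number, but the group entering in compound 4 is not the same, and no measured pair shows an ether at this position. The expectation is therefore a modest lowering, a 1.5-fold lower number from compound 3 to compound 4 (0.18 log units; within the scatter), with wide uncertainty. Compound 4 is estimated at 400 nM, between 100 nM and 1600 nM.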

Compound 4, half-maximal inhibitory concentration: 2250 nM
Compound 4: the middle estimate sits 5.6-fold (0.75 log units) below what was measured; measured number outside the range, above it.
By their numbers in this assay, from the lowest: compound 2; then compound 3; then compound 4; then compound 1.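

Replacing pyridin-3-yl with (3,5-dichloropyridin-2-yl)oxy at this position, para to a large group, gives a 3.7-fold higher number from compound 3 to compound 4 (0.57 log units; beyond the scatter), which means weaker inhibition. The earlier step, a 58-fold lower number from compound 1 to compound 2 (1.76 log units; beyond the scatter), showed only that phenyl in place of methyl goes with stronger inhibition, whereas this result shows that a larger group here does not always do so. No measurement available here accounts for the weaker inhibition of compound 4.

The oxygen link and the two chlorine atoms enter together, so the step cannot be divided between them. As far as these compounds go, how a plain phenoxy group, or a pyridin-2-yl ring joined through an amine nitrogen, would compare at this position remains open.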